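The compounds below may be only part of what the source reports. "The series", "measured", "known", "first", "only" and "open" are said of these compounds alone.

Compound 2, `N[C@@H](COP(=O)(O)OCCCOC(=O)CCc1ccccc1OCc1cccc(Oc2ccc(Cl)c(Cl)c2)c1)C(=O)O`, stands highest of the two compounds measured in an assay on cells for activation of probable G-protein coupled receptor 34 (Mus musculus), with a stated time of 1 h (on this read-out higher numbers stand for larger maximal responses and lower numbers for smaller maximal responses), where compound 2 gives 0.71. For the measured compounds named here, the only other measured compound, compound 1, `N[C@@H](COP(=O)(O)OCCCOC(=O)CCc1ccccc1OCc1cccc(OC2CCCCC2)c1)C(=O)O`, differs from it in the group on an oxygen on an aromatic ring; in this assay compound 1 gives 0.11. That single measured step, a number 0.60 higher from compound 1 to compound 2 (beyond the scatter), is the one that bears on the change considered here.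

Compound 3, `CCc1ccc(Oc2cccc(COc3ccccc3CCC(=O)OCCCOP(=O)(O)OC[C@H](N)C(=O)O)c2)cc1`, has not yet been measured. It differs from compound 2 as follows: 4-ethylphenyl in place of 3,4-dichlorophenyl on an oxygen on an aromatic ring. Both compound 2 and compound 3 carry a six-membered aromatic ring of carbon only in that place, whereas compound 1 carries cyclohexyl, so the change from compound 2 to compound 3 is smaller in kind than the measured step. Compound 3 is therefore expected to fall between the two measured values, closer to compound 2 than to compound 1, with the expected step from compound 2 being a number 0.21 lower from compound 2 to compound 3 (beyond the scatter). The estimate for compound 3 in this assay is 0.5, within a range from 0.25 to 0.78.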

Compound 3, intrinsic activity: the largest response reached, as a fraction of the reference agonist's: 0.42
Estimate against measurement, compound 3: 0.080 above, and the stated range covers the measured number.
By their numbers in this assay, from the lowest: compound 1; then compound 3; then compound 2.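

In this assay, having an aromatic ring on this oxygen does not fix the response: 4-ethylphenyl and 3,4-dichlorophenyl each bring one six-membered aromatic ring of carbon only and the same count of heavy atoms, yet the exchange gives a number 0.29 lower from compound 2 to compound 3 (beyond the scatter) and the result is clearly separated. Both aromatic groups still stand above cyclohexyl, with the second one giving a number 0.31 higher from compound 1 to compound 3 (beyond the scatter) as a step of its own. Nothing measured here accounts for the difference between the two aromatic groups.

The two groups differ both in their substituents and in where those sit on the ring, so these two effects cannot yet be told apart. As far as these compounds go, it remains open whether a plain phenyl or a 4-chlorophenyl on this oxygen would lie nearer compound 2 or compound 3.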